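The source may report more compounds than this note shows. Statements on the series, on what has been measured and on what is new or still open speak of the compounds shown alone.

Measured compounds:
- Compound 1 `Cc1ccc(/C=C(/C#N)C(=O)c2ccc[nH]2)cc1`: < 10000 nM in a functional assay on DU-145 cells (Homo sapiens) for cytotoxicity, read by MTT assay, with a stated time of 72 h; on this read-out lower numbers stand for stronger inhibition of growth and higher numbers for weaker inhibition of growth
- Compound 2 `N#C/C(=C/c1ccc(Cl)cc1)C(=O)c1ccc[nH]1`: 32000 nM
- Compound 3 `N#C/C(=C/c1ccc([N+](=O)[O-])cc1)C(=O)c1ccc[nH]1`: < 10000 nM

The value for compound 1 is a limit of this assay, not a number. The value for compound 3 is likewise a limit, and compound 3 therefore stands at the limit of < 10000 nM in this assay, at which 2 of the 3 values shown sit, rather than at a known point. Between the two numbers that can be compared, the step of an at least 3.2-fold lower number from compound 2 to compound 3 (0.50 log units; beyond the scatter) tells that the nitro compound does better than the chloro compound, while the step that the two limits leave unreadable from compound 1 to compound 3 cannot be read, as both ends are limits. The step of an at least 3.2-fold higher number from compound 1 to compound 2 (0.50 log units; beyond the scatter) is the only one with a readable direction besides it.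

Compound 4 `N#C/C(=C/c1ccc(O)cc1)C(=O)c1ccc[nH]1` differs from compound 3 in one place: hydroxy in place of nitro on an aromatic carbon. No measured step involves a hydroxy group, so nothing shown tells how far this change carries. Only the position of compound 3 at the limit, together with the step of an at least 3.2-fold lower number from compound 2 to compound 3 (0.50 log units; beyond the scatter), gives a footing: compound 3 is at least modestly better than compound 2, and the unknown hydroxy change could move in either direction.

Compound 4 is therefore estimated to sit near the limit, with a wide range, at 9000 nM (from 2000 nM to 40000 nM). This estimate means a step that the limit leaves unreadable from compound 3 to compound 4, which is expected to stay within the scatter.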

Compound 4, concentration for 50% growth inhibition: < 10000 nM
Compound 4: no number, only a limit; the forecaster's own chance of this, stated with the estimate: 40%; the middle value lies beyond the limit too.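

In this assay compound 4 gives < 10000 nM, which is a limit of the assay and not a number. Its hydroxy group, on the same aromatic carbon para to a large group, still allows a clear comparison with the chloro group of compound 2: an at least 3.2-fold lower number from compound 2 to compound 4 (0.50 log units; beyond the scatter). Nitro had already shown this direction against chloro, and hydroxy now shows that a much smaller group with a hydrogen-bond donor can do the same, so compound 2 is the one compound of the four that stands apart, while the steps from compound 1 and compound 3 to compound 4 cannot be read, as both ends of each are limits, and compound 4 joins the other two at: the limit of < 10000 nM in this assay, at which 3 of the 4 values shown sit.

Any order among compound 1, compound 3 and compound 4 stays open, and so does how far each lies past the limit, so the methyl, nitro and hydroxy groups cannot be told apart. As far as these compounds go, it is also open what an amine, a carboxylic acid or a longer chain such as an ethoxy group would give on this same aromatic carbon.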